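The source may hold more compounds than are shown below. What is called first, only, known or untested is meant among the compounds shown, and "the series" means these compounds.

Working notes on the series. Compound 1 `CC[C@H](C)[C@@H](NC(=O)Cn1cc(C2=C(c3c[nH]c4ccccc34)C(=O)N(C)C2=O)c2ccccc21)C(=O)OC` and compound 2 `COC(=O)CCNC(=O)Cn1cc(C2=C(c3c[nH]c4ccccc34)C(=O)N(C)C2=O)c2ccccc21` share a core and differ only in the group on the amide-type nitrogen. In a functional assay on A549 cells (Homo sapiens) for cytotoxicity, read by MTT assay, with a stated time of 24 h (a higher number here means a weaker inhibitor, a lower number a stronger inhibitor), compound 1 gives only a limit, > 100000 nM. In this assay, going by the values given here, compound 2 gives 37600 nM, the single number measured so far. Among the compounds with values here, the one measured step, an at least 2.6-fold lower number from compound 1 to compound 2 (0.42 log units; beyond the scatter), runs in favour of the smaller, unbranched group.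

Compound 3 `COC(=O)[C@@H](CO)NC(=O)Cn1cc(C2=C(c3c[nH]c4ccccc34)C(=O)N(C)C2=O)c2ccccc21` carries 2-hydroxy-1-(methoxycarbonyl)ethyl in place of 2-(methoxycarbonyl)ethyl on an amide-type nitrogen. This reintroduces branching at the carbon bearing the ester, the feature that distinguished compound 1, so a weaker result is expected, with an estimated step of a 1.9-fold higher number from compound 2 to compound 3 (0.27 log units; within the scatter). Compound 3 is therefore expected near 70000 nM, plausibly between 25000 nM and 200000 nM in this assay.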

Compound 3, half-maximal inhibitory concentration: 37900 nM
The estimate for compound 3 lay 1.8-fold (0.27 log units) above the measured number; the measured number falls inside the stated range.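

Branched and unbranched groups on the amide-type nitrogen are not told apart in this assay, with a 1.0-fold higher number from compound 2 to compound 3 (0.00 log units; within the scatter). Among the branched groups, hydroxymethyl in place of sec-butyl gives an at least 2.6-fold lower number from compound 1 to compound 3 (0.42 log units; beyond the scatter), so the step away from compound 1 does not require removing the branch. The value of compound 1 is a limit, so the full size of that step stays unknown: the limit of > 100000 nM in this assay, at which 1 of the 3 values shown sits.

Still open, from the compounds shown here alone, is whether a carboxylic acid in place of the methyl ester, or an amine on the chain, would shift the number in this assay.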